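The source may report more compounds than this note shows. Statements on the series, on what has been measured and on what is new or still open speak of the compounds shown alone.

Compound 1 `O=[N+]([O-])c1cccc(NS(=O)(=O)c2ccc(Br)cc2)c1` and compound 3 `O=[N+]([O-])c1ccc(S(=O)(=O)Nc2cccc([N+](=O)[O-])c2)cc1` share one core and differ in a single place: nitro in place of bromo on an aromatic carbon. In an ADME assay, compound 1 gives 7.42, while compound 3 gives 5.51. That step is a number 1.91 log units lower from compound 1 to compound 3 (beyond the scatter). Compound 2 `O=S(=O)(Nc1ccc(Cl)cc1)c1ccc(Br)cc1` stands highest of the three measured numbers, giving 8.24 in this assay; its distance to compound 1 and to compound 3 lies beyond the scatter in each case. How the core of compound 2 differs from the core of compound 1 is not broken down here.

Compound 4 `O=[N+]([O-])c1ccc(S(=O)(=O)Nc2ccc(Cl)cc2)cc1` has not been measured. It differs from compound 2 in one place: nitro in place of bromo on an aromatic carbon. This is the same change as that from compound 1 to compound 3, on the same kind of place, para to a large group, and among the compounds here it occurs twice in all. Among the measured compounds shown here, only one measured instance of it exists, so any expectation for compound 4 rests on that single step alone. For the measured compounds named here, because a number 1.91 log units lower from compound 1 to compound 3 (beyond the scatter) is the one measured example, the number for compound 4 in this assay is expected to sit a number 1.91 log units lower from compound 2 to compound 4 (beyond the scatter), a step of about the same size. The estimate for compound 4 is therefore 6.33, expected to fall between 5.85 and 6.8.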

Compound 4, acid dissociation constant: 6.24
The estimate for compound 4 lay 0.09 log units above the measured number, within the range that was stated.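

Nitro in place of bromo on an aromatic carbon now has a second reading in this assay, on a second core: a number 2.00 log units lower from compound 2 to compound 4 (beyond the scatter). Within these four compounds, the change carries from the core of compound 1 to the core of compound 2 with no difference in size that can be told apart: the same change on two cores in this assay, a number 1.91 log units lower (beyond the scatter) from compound 1 to compound 3 and a number 2.00 log units lower (beyond the scatter) from compound 2 to compound 4, 0.09 log units apart, within the scatter of two such steps This supports using the step as a working increment for these two cores, with the change para to a large group on a six-membered aromatic ring of carbon only, but two matched pairs do not establish it for other cores or other places, and neither pair says what sets the size of the step.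

The compounds shown hold only bromo or nitro at this place, so it remains open how an amine, a carboxylic acid or a nitrile there would read in this assay, and whether such groups would follow any similar increment. Also open, on these data alone, is whether the nitro-for-bromo step keeps its size on a core where the other substituent is neither nitro nor chloro, such as a methoxy group or a longer chain.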